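A Cyclopropyl Variant of a Glucagon Receptor Antagonist

The source may report more compounds than this note shows. Statements on the series, on what has been measured and on what is new or still open speak of the compounds shown alone.

Of the compounds shown here, two built on a shared core have been measured in an assay on CHO cells for displacement of a labelled ligand from Glucagon receptor (Homo sapiens), read by scintillation counting, with a stated time of 60 min; on this read-out lower numbers stand for stronger inhibition and higher numbers for weaker inhibition. Compound 1 `CCCCC[C@H](c1ccc(C(=O)NCc2nn[nH]n2)cc1)N1C(=O)C(c2cc(Cl)cc(Cl)c2)=N[C@]12CC[C@@H](C(C)(C)C)CC2` gives 24 nM in this assay. Compound 2 `C[C@H](c1ccc(C(=O)NCCC(=O)O)cc1)N1C(=O)C(c2ccccc2F)=N[C@]12CC[C@@H](C(C)(C)C)CC2` differs from compound 1 at several places at once; in this assay compound 2 gives 1100 nM. Compound 1 therefore stands at the lowest of the two numbers, and its gap to compound 2 lies beyond the usual scatter. Among the compounds with values here, no step between measured compounds that differ in a single place exists here, so these two values show only that several changes made together can move the number a long way.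

Compound 3 `CC1(CC[C@H](c2ccc(C(=O)NCc3nn[nH]n3)cc2)N2C(=O)C(c3cc(Cl)cc(Cl)c3)=N[C@]23CC[C@@H](C(C)(C)C)CC3)CC1` has not yet been measured. It differs from compound 1 in one place: 1-methylcyclopropyl in place of propyl on a saturated chain carbon, three bonds along the chain from an amide-type nitrogen in a ring and an aromatic carbon. Neither measured compound speaks to this particular change, since compound 2 alters the chain together with two other groups. The step is expected to be small, with no clear direction and possibly none beyond the scatter. Compound 3 is thus expected to give 28 nM in this assay, with a range from 10 nM to 80 nM. This corresponds to an expected 1.2-fold higher number from compound 1 to compound 3 (0.07 log units; within the scatter).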

Compound 3, half-maximal inhibitory concentration: 17 nM
For compound 3 the middle estimate is 1.6-fold (0.22 log units) above the measured one; measured number inside the range.
By their numbers in this assay, from the lowest: compounds 3 and 1 (each within the scatter of the next); then compound 2.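

In this assay, putting 1-methylcyclopropyl in place of propyl on a saturated chain carbon, three bonds along the chain from an amide-type nitrogen in a ring and an aromatic carbon, gives a 1.4-fold lower number from compound 1 to compound 3 (0.15 log units; within the scatter). Within the data shown here, the earlier pair could not show this, since compound 2 changes the chain together with other groups; the single change now shows that pentyl can give way to 2-(1-methylcyclopropyl)ethyl, which brings in a three-membered carbon ring and one more carbon, without a step beyond the scatter. Nothing shown here offers a measured explanation for the two numbers staying within the scatter of each other.

Going by these compounds, what remains open is how far this position stays so undemanding once the chain end carries something other than carbon alone, such as an amine or a hydroxyl group, or a larger ring such as phenyl. Also unresolved is whether plain cyclopropyl, without its methyl group, would behave like 1-methylcyclopropyl, and whether the same swap would give a similar step with other groups elsewhere on the shared core.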